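The source may report more compounds than this note shows. Statements on the series, on what has been measured and on what is new or still open speak of the compounds shown alone.

Measured so far in a functional assay on CRL2813 cells (Homo sapiens) for cytotoxicity, read by sulforhodamine B assay, with a stated time of 5 days; a lower number here means a stronger inhibitor, a higher number a weaker inhibitor:
- compound 1 `O=C(Nc1ccc(Br)cc1)N[C@H]1CC[C@H](Oc2ccc(F)cc2)CC1`: > 20000 nM (a limit of the assay, not a number)
- compound 2 `COC(=O)c1ccc(NC(=O)N[C@H]2CC[C@H](Oc3ccc(F)cc3)CC2)cc1`: 11600 nM
- compound 3 `O=C(Nc1cccc(C(F)(F)F)c1)N[C@H]1CC[C@H](Oc2cccc(F)c2)CC1`: 2400 nM

Compound 1 stands at the weak end of what is shown: its result is only a limit, (the limit of > 20000 nM in this assay, at which 1 of the 3 values shown sits). Going by the values given here, the one step that starts from it, an at least 1.7-fold lower number from compound 1 to compound 2 (0.23 log units; that floor lies within the scatter), is small and sits within the scatter, so a change on the aromatic ring that hangs on the urea nitrogen has so far not moved this assay in a clear way. Among the compounds with values here, compound 3 carries a differently placed fluoro on the ether ring as well as a different group on the urea-side ring; no single step links it to compound 1, and its two values show only that compound 3 is measurable where compound 1 is not.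

Compound 4 `O=C(Nc1cccc(F)c1)N[C@H]1CC[C@H](Oc2ccc(F)cc2)CC1` differs from compound 1 by 3-fluorophenyl in place of 4-bromophenyl on an amide-type nitrogen. Within the data shown here, no measured step covers this exchange. Because an at least 1.7-fold lower number from compound 1 to compound 2 (0.23 log units; that floor lies within the scatter) was within the scatter, the expectation is a modest improvement at best: the estimated step is an at least 2.0-fold lower number from compound 1 to compound 4 (0.30 log units; that floor lies within the scatter). Compound 4 is therefore expected to give about 10000 nM in this assay, within 3000 nM to 30000 nM.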

Compound 4, half-maximal inhibitory concentration: 8300 nM
Beside the measured number, compound 4's estimate is 1.2-fold (0.08 log units) above it, and the stated range covers the measured number.
By their numbers in this assay, from the lowest: compound 3; then compounds 4 and 2 (each within the scatter of the next). At a limit, above all of these: compound 1.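

In this assay, 3-fluorophenyl in place of 4-bromophenyl on an amide-type nitrogen gives an at least 2.4-fold lower number from compound 1 to compound 4 (0.38 log units; beyond the scatter), so this exchange clears the scatter. The earlier step at this position, an at least 1.7-fold lower number from compound 1 to compound 2 (0.23 log units; that floor lies within the scatter), did not, so the group on this nitrogen is now shown to be able to shift the read-out, at least for this pair. The true size of the step remains unknown, and its printed value is only a floor, because the value of compound 1 is a limit and not a number: the limit of > 20000 nM in this assay, at which 1 of the 4 values shown sits.

The exchange changes the halogen and its place on the ring together, and the compounds shown do not separate these two changes. Also open, from the compounds shown here alone, is how 3-bromophenyl, 4-fluorophenyl, or a phenyl ring bearing an amine or a carboxylic acid would read on this nitrogen in this assay with the rest of the core of compound 4 kept the same.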